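Moving the nitrile on the ring-nitrogen aryl group

This account rests on a few compounds, and the source may have more. Where it says the series, first, only, none or still open, it means among the compounds named here.

Three measured compounds share one core and differ only in the aryl group on the ring nitrogen. In an ADME assay on microsomes from liver (Rattus norvegicus) for metabolic stability, read by LC-MS, using NADPH (a higher number here means that the compound lasts longer, a lower number that the compound disappears faster), compound 1 `O=C(NCCCCN1CCN(c2ccc(Cl)cc2Cl)CC1)c1ccc(-c2ccsc2)cc1` gives 0.3 h, compound 2 `O=C(NCCCCN1CCN(c2cccc(O)c2)CC1)c1ccc(-c2ccsc2)cc1` gives 0.085 h, and compound 3 `N#Cc1ccccc1N1CCN(CCCCNC(=O)c2ccc(-c3ccsc3)cc2)CC1` gives 0.0333 h. Compound 3 holds the lowest number of the three: the nearest is compound 2, a 2.6-fold lower number from compound 2 to compound 3 (0.41 log units; beyond the scatter), and the furthest is compound 1, a 9.0-fold lower number from compound 1 to compound 3 (0.95 log units; beyond the scatter). Between the other two, a 3.5-fold lower number from compound 1 to compound 2 (0.55 log units; beyond the scatter).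

Compound 4 `N#Cc1ccc(N2CCN(CCCCNC(=O)c3ccc(-c4ccsc4)cc3)CC2)cc1` is not yet measured. Against compound 3 the change is 4-cyanophenyl in place of 2-cyanophenyl on an amine nitrogen in a ring. Among the measured compounds shown here, no measured step keeps the same atoms joined differently; the three recorded steps all swap one aryl group for another of different composition, and each moved the number beyond the scatter, though only modestly. A change smaller than any of those is involved here, so no step beyond the scatter is expected, in either direction. The expected step is a 1.2-fold higher number from compound 3 to compound 4 (0.08 log units; within the scatter), a small one. The estimate for compound 4 in this assay is 0.04 h, with a range of 0.015 h to 0.11 h.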

Compound 4, half-life: 0.22 h
Estimate against measurement, compound 4: 5.5-fold (0.74 log units) below, outside the stated range (above it).
By their numbers in this assay, from the lowest: compound 3; then compound 2; then compounds 4 and 1 (each within the scatter of the next).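

In this assay, among the compounds shown here, the same atoms joined differently give a 6.6-fold higher number from compound 3 to compound 4 (0.82 log units; beyond the scatter) with 4-cyanophenyl in place of 2-cyanophenyl, so where the nitrile sits on the aryl group moves the half-life even with composition unchanged, which the earlier steps, all between groups of different composition, could not show. The 4-cyanophenyl group also gives a 2.6-fold higher number from compound 2 to compound 4 (0.41 log units; beyond the scatter) against 3-hydroxyphenyl and a 1.4-fold lower number from compound 1 to compound 4 (0.13 log units; within the scatter) against 2,4-dichlorophenyl, so among these compounds a nitrile on the aryl group does not by itself go with a short half-life. Nothing at hand explains the gap between the two nitrile positions.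

Where a 3-cyanophenyl group would fall stays open. So does whether a 4-methoxyphenyl or 2-methoxyphenyl pair shows the same gap, or whether the gap survives a shorter chain.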